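Moving the butyl branch: from compound 2 to compound 3

A few compounds are considered here, and "the series" means these few. Any claim that something is new, unique, unknown or untested is made for them only; others in the source may bear on it.

- compound 1 `CCCNC(=O)Nc1ccc(C(C)(C)C)cc1` gives 30000 nM
- compound 2 `CCNC(=O)Nc1ccc(C(C)CC)cc1` gives 101000 nM

In a functional assay on K562 cells (Homo sapiens) (on this read-out lower numbers stand for stronger inhibition and higher numbers for weaker inhibition), compound 2 gives 101000 nM, the higher of the two numbers, and the gap to compound 1 at 30000 nM lies beyond the scatter. Compound 3 `CCNC(=O)Nc1ccc(C(C)(C)C)cc1` has not yet been measured. It is made from compound 2 by one exchange, tert-butyl in place of sec-butyl on an aromatic carbon. For the measured compounds named here, no measured pair isolates this exchange. Compound 1 carries the same tert-butyl group, with propyl where compound 3 has ethyl, and the value of compound 1, 30000 nM, suggests a shift toward lower numbers in this assay. That shift is expected to be small and to stay within the scatter, and the estimated size is a 1.8-fold lower number from compound 2 to compound 3 (0.26 log units; within the scatter). For compound 3 the expected value is 55000 nM, within an estimated range of 25000 nM to 120000 nM.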

Compound 3, half-maximal inhibitory concentration: 84000 nM
Compound 3: middle estimate off by 1.5-fold (0.18 log units), on the low side, within the range that was stated.
By their numbers in this assay, from the lowest: compound 1; then compounds 3 and 2 (each within the scatter of the next).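

In this assay, the shape of the butyl branch on the aromatic carbon makes little difference: tert-butyl in place of sec-butyl gives a 1.2-fold lower number from compound 2 to compound 3 (0.08 log units; within the scatter), so this exchange alone does not separate the two compounds. The saturated chain does make a difference, as shortening propyl to ethyl gives a 2.8-fold higher number from compound 1 to compound 3 (0.45 log units; beyond the scatter), a modest step but one that lies beyond the scatter. Nothing available offers an explanation for either step.

From the compounds shown here alone, whether a longer chain, such as butyl or pentyl, would carry the numbers lower still remains open, as this single step cannot show a trend with chain length. Also open, going by these compounds, is how an amine or a carboxylic acid would read in this assay if it stood in place of the tert-butyl group on the aromatic carbon.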